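Swapping the Aryl Group in an Inactive Chalcone Pair

This account rests on a few compounds, and the source may have more. Where it says the series, first, only, none or still open, it means among the compounds named here.

Of the compounds shown here, two built on the same core have been tested in a functional assay on BGC-823 cells (Homo sapiens) for cytotoxicity, read by MTT assay; on this read-out higher numbers stand for weaker inhibition and lower numbers for stronger inhibition. Compound 1 `COc1cccc(/C=C/C(=O)c2sc(Nc3ccc(Cl)cc3)nc2C)c1` gave only a limit of the assay, > 25000 nM. Compound 2 `Cc1ccc(Nc2nc(C)c(C(=O)/C=C/c3ccc(Cl)cc3)s2)cc1` likewise gave only a limit of the assay, > 25000 nM. Among the compounds with values here, compound 2 therefore stands at the ceiling of what the assay reports, and the one other value shown sits at that same ceiling (the limit of > 25000 nM in this assay, at which 2 of the 2 values shown sit); no number separates the two.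

Compound 3 `COc1cccc(/C=C/C(=O)c2sc(Nc3ccc(C)cc3)nc2C)c1` has not yet been measured. Relative to compound 2 the change is 3-methoxyphenyl in place of 4-chlorophenyl on a double-bonded chain carbon bound to a double-bonded chain carbon. Compound 3 thus carries the 3-methoxyphenyl found in compound 1 together with the amine-side group of compound 2, and both of those parents sit at the limit. Within the data shown here, no measured pair differs in only one place, and no step size is known. The expectation for compound 3 is no movement beyond the scatter, with a step that the limit leaves unreadable from compound 2 to compound 3 expected to be essentially none and the assay most likely again reporting only a limit. The expected value for compound 3 is 30000 nM, within a range of 10000 nM to 100000 nM.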

Compound 3, half-maximal inhibitory concentration: > 25000 nM
Compound 3: a limit, no number; the forecaster's own chance of this, stated with the estimate: 85%; the middle value is on the limit's open side.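

In this assay compound 3, like compound 1 and compound 2, gives only a limit, so neither the step from compound 1 nor the step from compound 2 to compound 3 can be read: the limit of > 25000 nM in this assay, at which 3 of the 3 values shown sit.

The compounds shown leave open whether any change on the shared core brings a real number in this assay and how large such a step would be.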